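Trimming the Chain End of Compound 1

The source may hold more compounds than are shown below. What is called first, only, known or untested is meant among the compounds shown, and "the series" means these compounds.

Measured compounds:
compound 1 `CN1CCN(CCCCn2c3c(c4ccccc42)C(=O)c2c[n+]([O-])c4ccccc4c2C3=O)CC1` with 10 nM
compound 2 `CC1(C)OC[C@H](Cn2cc(Cn3c4c(c5ccccc53)C(=O)c3c[n+]([O-])c5ccccc5c3C4=O)nn2)O1` with 130 nM
compound 3 `O=C1c2c[n+]([O-])c3ccccc3c2C(=O)c2c1c1ccccc1n2Cc1cn([C@H]2C[C@H](O)[C@@H](CO)O2)nn1` with 120 nM

In a functional assay on HCT-116 cells (Homo sapiens) for cytotoxicity, read by MTT assay, with a stated time of 72 h (a lower number here means a stronger inhibitor, a higher number a weaker inhibitor), compound 1 gives 10 nM, the lowest of the three numbers. Compound 3 gives 120 nM and compound 2 gives 130 nM, both beyond the scatter from compound 1. Going by the values given here, the only measured pair differing in one place is compound 2 against compound 3, where the change sits on the aromatic nitrogen: a 1.1-fold lower number from compound 2 to compound 3 (0.03 log units; within the scatter). That step concerns a different part of the molecule and says nothing about the chain end varied here.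

Compound 4 `CN(C)CCCCn1c2c(c3ccccc31)C(=O)c1c[n+]([O-])c3ccccc3c1C2=O` is compound 1 with dimethylamino in place of 4-methylpiperazin-1-yl on a saturated chain carbon, four bonds along the chain from an aromatic nitrogen. Among the compounds with values here, no measured pair touches this position, so the expectation rests on compound 1 alone. Compound 4 is expected to stay close to compound 1, with a step of a 1.5-fold higher number from compound 1 to compound 4 (0.18 log units; within the scatter) that is not expected to clear the scatter. Compound 4 is therefore estimated at 15 nM, within a range from 5 nM to 50 nM.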

Compound 4, half-maximal inhibitory concentration: 450 nM
Beside the measured number, compound 4's estimate is 30-fold (1.48 log units) below it; the whole stated range lies below it.
By their numbers in this assay, from the lowest: compound 1; then compounds 3 and 2 (each within the scatter of the next); then compound 4.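

The chain end of compound 1 proves to be no free exchange. In this assay, going by these compounds alone, dimethylamino in place of 4-methylpiperazin-1-yl on a saturated chain carbon, four bonds along the chain from an aromatic nitrogen, gives a 45-fold higher number from compound 1 to compound 4 (1.65 log units; beyond the scatter) and so marks this position as one where a single change has a large effect, which the only earlier step, a 1.1-fold lower number from compound 2 to compound 3 (0.03 log units; within the scatter), could not show because it concerned a different part of the molecule. Nothing available here accounts for the size of this step.

The compounds shown leave open whether another ring at the chain end, such as morpholin-4-yl or piperidin-1-yl, would stay near compound 1 or fall nearer compound 4. They also leave open whether the same exchange would produce a step of similar size on a shorter or a longer chain.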